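Amide substituent changes across a shared core series

The compounds below may be only part of what the source reports. "The series", "measured", "known", "first", "only" and "open" are said of these compounds alone.

Three measured compounds share one core and differ only in the group on the amide-type nitrogen. Compound 1 `CCNC(=O)CCc1cccc2c1B(O)OC2` carries ethyl there. In a functional assay on SK-OV-3 cells (Homo sapiens) for antiproliferative activity, read by MTT assay, with a stated time of 72 h (a higher number here means a weaker inhibitor, a lower number a stronger inhibitor), compound 1 gives only a limit, > 100000 nM; this is the limit of > 100000 nM in this assay, at which 1 of the 3 values shown sits. Compound 2 `O=C(CCc1cccc2c1B(O)OC2)Nc1ccc(Br)cc1` carries 4-bromophenyl, and in this assay compound 2 gives 9200 nM. Compound 3 `CC(C)c1cccc(NC(=O)CCc2cccc3c2B(O)OC3)c1` carries an isopropyl-bearing phenyl, and in this assay compound 3 gives 510 nM, the lowest of the two numbers, separated from compound 2 by a gap beyond the scatter.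

One single-point step is measured: an at least 10-fold lower number from compound 1 to compound 2 (1.03 log units; beyond the scatter). It shows that an aryl group on the nitrogen in place of a short alkyl lowers the number strongly.

Compound 4 `CSc1cccc(-c2cccc(NC(=O)CCc3cccc4c3B(O)OC4)c2)c1` is the next compound, not yet measured. The change is 3-(methylsulfanyl)phenyl in place of isopropyl on an aromatic carbon. Among the measured compounds shown here, no measured step swaps one aryl substituent for another; the step from compound 1 to compound 2 concerns a different position and bears on this change only loosely, as a sign that added aryl content has so far lowered the number. For the measured compounds named here, with only two numbers, no pattern is claimed. The expected outcome for compound 4 is a step within the scatter or a small lowering, a 1.7-fold lower number from compound 3 to compound 4 (0.23 log units; within the scatter). The estimate for compound 4 is 300 nM, with a range from 70 nM to 1500 nM.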

Compound 4, half-maximal inhibitory concentration: 150 nM
Estimate against measurement, compound 4: 2.0-fold (0.30 log units) above; measured number inside the range.
By their numbers in this assay, from the lowest: compound 4; then compound 3; then compound 2. At a limit, above all of these: compound 1.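

In this assay, among the compounds shown here, the exchange of isopropyl for 3-(methylsulfanyl)phenyl gives a 3.4-fold lower number from compound 3 to compound 4 (0.53 log units; beyond the scatter) and is the first measured swap of one substituent for another on this aromatic ring, a modest step but one that exceeds the scatter. The position, on an aromatic carbon meta to a large group, therefore takes a substituent of 8 heavy atoms with a whole further aromatic ring in place of one of 3 heavy atoms and no ring, and the number still falls rather than rises. Nothing measured in this series gives a cause for this step.

The compounds shown leave open whether the step belongs to the added phenyl ring itself or to the methylsulfanyl group on it: a plain phenyl, or a phenyl carrying an amine or a carboxylic acid in place of methylsulfanyl, would separate the two. Also open, from the compounds shown here alone, is how a simple longer chain, such as n-butyl, would compare with isopropyl on the same aromatic carbon, which would show whether a second ring is needed at all.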